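The source may hold more compounds than are shown below. What is called first, only, known or untested is meant among the compounds shown, and "the series" means these compounds.

In a functional assay on HepG2 cells (Homo sapiens) for inhibition, read by MTT assay, with a stated time of 48 h (on this read-out lower numbers stand for stronger inhibition and higher numbers for weaker inhibition), compound 1 (`Cc1ccc(OCc2cn(-c3ccc(NS(C)(=O)=O)c(Oc4ccccc4)c3)nn2)cc1`) gives 13000 nM. In this assay compound 2 (`Cc1ccc(-c2cn(-c3ccc(NS(C)(=O)=O)c(Oc4ccccc4)c3)nn2)cc1`) gives 18300 nM. Within the data shown here, these are the only two numbers so far, and they lie within the scatter of each other, so compound 1 cannot be ranked apart from compound 2. Compound 3 (`CS(=O)(=O)Nc1ccc(-n2cc(COc3ccc(Cl)cc3)nn2)cc1Oc1ccccc1`) keeps the core of compound 1 and differs by chloro in place of methyl on an aromatic carbon: (4-chlorophenoxy)methyl in place of (4-methylphenoxy)methyl, with the chloro para to a large group. Among the measured compounds shown here, the only measured step, a 1.4-fold higher number from compound 1 to compound 2 (0.15 log units; within the scatter), exchanges the whole (4-methylphenoxy)methyl for 4-methylphenyl and leaves the methyl in place. For the measured compounds named here, no measured pair tests chloro against methyl directly. A step beyond the scatter is therefore not expected in this assay, and no direction can be drawn from the data. The estimate for compound 3 is 12000 nM, with an expected range of 6000 nM to 25000 nM. The estimated change is a 1.1-fold lower number from compound 1 to compound 3 (0.03 log units; within the scatter).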

Compound 3, half-maximal inhibitory concentration: 7500 nM
Compound 3: the middle estimate sits 1.6-fold (0.20 log units) above what was measured; measured number inside the range.
By their numbers in this assay, from the lowest: compounds 3, 1 and 2 (each within the scatter of the next, the first and the last beyond it).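

In this assay, chloro in place of methyl on the aromatic carbon para to a large group gives a 1.7-fold lower number from compound 1 to compound 3 (0.24 log units; within the scatter), so at this position the exchange cannot be told apart from repeat measurement. Against the 4-methylphenyl of compound 2, the (4-chlorophenoxy)methyl group gives a 2.4-fold lower number from compound 2 to compound 3 (0.39 log units; beyond the scatter), the first step in the series beyond the scatter, though a modest one, and it exchanges more than the chloro alone, so it cannot be credited to the chloro. Nothing measured here bears on the origin of either step.

As far as these compounds go, whether this position accepts anything other than methyl or chloro, such as an amine, a methoxy or a carboxylic acid, stays open. Also open, from the compounds shown here alone, is whether 4-chlorophenyl in place of the 4-methylphenyl of compound 2 would shift the number.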